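The source may report more compounds than this note shows. Statements on the series, on what has been measured and on what is new or still open speak of the compounds shown alone.

Compound 1, with the structure `COc1ccc(C(=O)/C=C/c2ccc(OCc3cn(Cc4cccc(Br)c4)nn3)cc2)cc1`, gives 45% in a functional assay on MCF7 cells (Homo sapiens) for inhibition, read by MTT assay, with a stated time of 48 h, tested at 10 uM; on this read-out higher numbers stand for more inhibition of growth at the one concentration tested and lower numbers for less inhibition of growth. Compound 2, with the structure `COc1ccc(C(=O)/C=C/c2ccc(OCc3cn(Cc4ccc(Br)cc4)nn3)cc2)cc1`, differs from compound 1 only by 4-bromophenyl in place of 3-bromophenyl on a saturated chain carbon bound to an aromatic nitrogen, and in this assay compound 2 gives 53%, so that the step is a number 8 percentage points higher from compound 1 to compound 2 (within the scatter). Compound 3, with the structure `O=C(/C=C/c1ccc(OCc2cn(Cc3cccc(Br)c3)nn2)cc1)c1ccc([N+](=O)[O-])cc1`, shares the core of compound 1 but carries nitro in place of methoxy on an aromatic carbon; in this assay compound 3 gives 12%, a step of a number 33 percentage points lower from compound 1 to compound 3 (beyond the scatter), which leaves compound 3 as the lowest of the three measured numbers. Compound 4, with the structure `O=C(/C=C/c1ccc(OCc2cn(Cc3ccc(Br)cc3)nn2)cc1)c1ccc([N+](=O)[O-])cc1`, has not yet been measured in this assay. It differs from compound 3 by 4-bromophenyl in place of 3-bromophenyl on a saturated chain carbon bound to an aromatic nitrogen, the same change that separates compound 1 from compound 2, made at the same place. Because that earlier step, a number 8 percentage points higher from compound 1 to compound 2 (within the scatter), stayed within the scatter, compound 4 is expected to stay close to compound 3, and the step from compound 3 to compound 4 is estimated as a number 6 percentage points higher from compound 3 to compound 4 (within the scatter). On that basis compound 4 is estimated to give 18% in this assay, expected to lie between 5% and 32%.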

Compound 4, percent growth inhibition at one concentration: 18%
Estimate against measurement, compound 4: no gap at the digits printed; measured number inside the range.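

In this assay, 4-bromophenyl in place of 3-bromophenyl gives a number 6 percentage points higher from compound 3 to compound 4 (within the scatter), and this change behaves alike on both cores: the same change on two cores in this assay, a number 8 percentage points higher (within the scatter) from compound 1 to compound 2 and a number 6 percentage points higher (within the scatter) from compound 3 to compound 4, 2 percentage points apart, within the scatter of two such steps. Nitro in place of methoxy gives a number 35 percentage points lower from compound 2 to compound 4 (beyond the scatter), and this large step also carries over from the core of compound 1 to the core of compound 2: the same change on two cores in this assay, a number 33 percentage points lower (beyond the scatter) from compound 1 to compound 3 and a number 35 percentage points lower (beyond the scatter) from compound 2 to compound 4, 2 percentage points apart, within the scatter of two such steps. Within these four compounds, each change keeps its size on either core, but that rests on a single pair of steps per change at one concentration, and it does not show that either change would carry over to any other core, nor that moving the bromine makes a difference, as both of those steps stay within the scatter.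

The compounds shown leave open whether the large step belongs to nitro itself or would also appear with another group in its place, such as an amine or a carboxylic acid. They also leave open how a longer chain, in place of the single saturated carbon bound to the aromatic nitrogen, would read.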